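The source may hold more compounds than are shown below. What is called first, only, known or untested is meant among the compounds shown, and "the series" means these compounds.

Compound 3 `CCCCN1CCN(CCCCn2c3c(c4ccccc42)C(=O)c2c[n+]([O-])c4ccccc4c2C3=O)CC1` gives 1920 nM in a functional assay on HCT-116 cells (Homo sapiens) for cytotoxicity, read by MTT assay, with a stated time of 72 h (on this read-out higher numbers stand for weaker inhibition and lower numbers for stronger inhibition), and so stands at the highest of the three numbers measured. Compound 2 `CCCN1CCN(CCCCn2c3c(c4ccccc42)C(=O)c2c[n+]([O-])c4ccccc4c2C3=O)CC1` gives 790 nM and compound 1 `O=C1c2c[n+]([O-])c3ccccc3c2C(=O)c2c1c1ccccc1n2Cc1cn(CC(O)CO)nn1` gives 250 nM in this assay. The change to compound 4 `O=C1c2c[n+]([O-])c3ccccc3c2C(=O)c2c1c1ccccc1n2CCCN1CCC(O)CC1` is 4-hydroxypiperidin-1-yl in place of (4-butylpiperazin-1-yl)methyl on a saturated chain carbon, three bonds along the chain from an aromatic nitrogen. The two measured steps touch the same region: a 3.2-fold higher number from compound 1 to compound 2 (0.50 log units; beyond the scatter) and a 2.4-fold higher number from compound 2 to compound 3 (0.39 log units; beyond the scatter), both modest rises as the side group grew. Compound 4 loses the butylpiperazine entirely and gains a hydroxyl, a move toward the smaller, hydroxyl-bearing side group of compound 1, so a modestly lower number is expected, with a 2.4-fold lower number from compound 3 to compound 4 (0.38 log units; beyond the scatter). Compound 4 is estimated at 800 nM, within roughly 300 nM to 2500 nM.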

Compound 4, half-maximal inhibitory concentration: 190 nM
Compound 4: middle estimate off by 4.2-fold (0.62 log units), on the high side; the whole stated range lies above it.
By their numbers in this assay, from the lowest: compounds 4 and 1 (each within the scatter of the next); then compound 2; then compound 3.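

In this assay, replacing the alkylpiperazine side groups with 4-hydroxypiperidin-1-yl gives a 10-fold lower number from compound 3 to compound 4 (1.00 log units; beyond the scatter) and a 4.2-fold lower number from compound 2 to compound 4 (0.62 log units; beyond the scatter), so the numbers at this position can fall as well as rise. Two quite different hydroxyl-bearing side groups also give a 1.3-fold lower number from compound 1 to compound 4 (0.12 log units; within the scatter), and so cannot be told apart here. Nothing available explains these shifts.

From the compounds shown here alone, whether the hydroxyl or the loss of the alkylpiperazine matters more stays open. A plain piperidine without the hydroxyl, or a morpholine, on the same chain would separate the two.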